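Replacing tert-butyl on a carbonyl carbon: a solubility estimate

The source may report more compounds than this note shows. Statements on the series, on what has been measured and on what is new or still open speak of the compounds shown alone.

Measured in a physicochemical assay for solubility, read by HPLC, in phosphate buffer, measured as kinetic solubility, at pH 7.4; on this read-out higher numbers stand for higher solubility and lower numbers for lower solubility:

Compound 1 `CC(C)(C)C(=O)c1cc(-c2ccc(S(N)(=O)=O)cc2)n(-c2ccc(Cl)cc2)n1`: 6600 nM
Compound 2 `CCC(=O)c1cc(-c2ccc(S(N)(=O)=O)cc2)n(-c2ccc(C(F)(F)F)cc2)n1`: 7500 nM
Compound 3 `CCC(=O)c1cc(-c2ccc(S(N)(=O)=O)cc2)n(-c2cccc(Cl)c2)n1`: 6900 nM

Compound 1, at 6600 nM, stands level with compound 2 and compound 3, since all three values agree within the usual scatter. Compound 4 `NS(=O)(=O)c1ccc(-c2cc(C(=O)N3CC4CC4C3)nn2-c2ccc(Cl)cc2)cc1` is still unmeasured. It keeps the core of compound 1 and changes one group: a group of 6 heavy atoms (5 carbon, 1 nitrogen; one three-membered non-aromatic ring of carbon only, one five-membered non-aromatic ring with 1 hetero atom) in place of a group of 4 heavy atoms (4 carbon; no ring), on a carbonyl carbon. Going by the values given here, no pair of measured compounds differs in one place only, so the data offer no direct guide to this change in this assay. The expectation is therefore no step beyond the scatter, in either direction. The expected step is a 1.2-fold higher number from compound 1 to compound 4 (0.08 log units; within the scatter). For compound 4 the estimated value is 8000 nM, with a range of 3000 nM to 20000 nM.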

Compound 4, solubility: 36600 nM
Estimate against measurement, compound 4: 4.6-fold (0.66 log units) below, outside the stated range (above it).
By their numbers in this assay, from the lowest: compounds 1, 3 and 2 (each within the scatter of the next); then compound 4.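

In this assay, putting the group with one three-membered and one five-membered ring in place of tert-butyl on the carbonyl carbon gives a 5.5-fold higher number from compound 1 to compound 4 (0.74 log units; beyond the scatter) on the shared core. Going by these compounds alone, this is the first step at this position read with only one place changed, and it shows that the position can move the number beyond the scatter. Nothing measured here explains the step.

As far as these compounds go, whether the three-membered ring matters, or the nitrogen on the carbonyl carbon alone, stays open. The compounds shown hold no pyrrolidine or dimethylamino group there to separate the two.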